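Carboxypyridinyl analogue of the tetrazolyl ketone: expected potency

This account rests on a few compounds, and the source may have more. Where it says the series, first, only, none or still open, it means among the compounds named here.

Compound 3 `O=C(CCc1ccc(COc2ccccc2)cc1)c1ncc(-c2cccc(-c3nnn[nH]3)n2)o1` gives 21 nM in an assay for inhibition of Fatty-acid amide hydrolase 1 (Rattus norvegicus) (on this read-out lower numbers stand for stronger inhibition and higher numbers for weaker inhibition), the highest of the three numbers. Compound 1 `CN(C)C(=O)c1cnc(C(=O)CCc2ccc(COc3ccccc3)cc2)o1` gives 6.7 nM and compound 2 `N#Cc1cccc(-c2cnc(C(=O)CCc3ccc(COc4ccccc4)cc3)o2)n1` gives 0.56 nM; the steps are a 3.1-fold higher number from compound 1 to compound 3 (0.50 log units; beyond the scatter) and a 38-fold higher number from compound 2 to compound 3 (1.57 log units; beyond the scatter). Compound 4 `O=C(O)c1ccc(-c2cnc(C(=O)CCc3ccc(COc4ccccc4)cc3)o2)nc1` differs from compound 3 in one place: 5-carboxypyridin-2-yl in place of 6-(1H-tetrazol-5-yl)pyridin-2-yl on an aromatic carbon. Within the data shown here, no measured step covers a carboxy group. The nearest comparison is the entry of the 1H-tetrazol-5-yl group, a 38-fold higher number from compound 2 to compound 3 (1.57 log units; beyond the scatter), a large loss, which leaves compound 3 the weakest of the set. With one hydrogen-bond donor again carried on the pyridine, compound 4 is expected to stay near compound 3, the step of a 1.2-fold higher number from compound 3 to compound 4 (0.08 log units; within the scatter) expected to lie within or barely beyond the scatter. Compound 4 is therefore estimated at 25 nM, range 6 nM to 100 nM.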

Compound 4, inhibition constant: 4.6 nM
Estimate against measurement, compound 4: 5.4-fold (0.74 log units) above, and the stated range ends above it.
By their numbers in this assay, from the lowest: compound 2; then compounds 4 and 1 (each within the scatter of the next); then compound 3.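

The tetrazole-to-carboxy change shows that the group on this aromatic carbon still tunes the number when both groups count one hydrogen-bond donor (a 4.6-fold lower number from compound 3 to compound 4 (0.66 log units; beyond the scatter)). The 5-carboxypyridin-2-yl group does not match 6-cyanopyridin-2-yl (an 8.2-fold higher number from compound 2 to compound 4 (0.91 log units; beyond the scatter)), and it sits level with the dimethylcarbamoyl group (a 1.5-fold lower number from compound 1 to compound 4 (0.16 log units; within the scatter)). No measured evidence bears on the reason for these steps.

The carboxy group and its place on the pyridine change together, so their contributions remain unseparated. A 6-carboxypyridin-2-yl group would separate them.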